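A new chain end for compound 3

The compounds below may be only part of what the source reports. "The series", "measured", "known", "first", "only" and "open" are said of these compounds alone.

Measured in a functional assay on SH-SY5Y cells (Homo sapiens) for antiproliferative activity, read by MTT assay, with a stated time of 72 h; a higher number here means a weaker inhibitor, a lower number a stronger inhibitor:
- compound 1 `COc1cc2c(Nc3ccc(C#N)cc3)ncnc2cc1OCCCN1CCCC1`: 8080 nM
- compound 2 `CCOC(=O)C1CCN(CCCOc2cc3ncnc(Nc4ccc(C#N)cc4)c3cc2OC)CC1`: 47200 nM
- compound 3 `COc1cc2c(Nc3ccc(C#N)cc3)ncnc2cc1OCCCN1CCc2ccccc2C1`: > 100000 nM (a limit)

In this assay, compound 3 stands only at a limit: the limit of > 100000 nM in this assay, at which 1 of the 3 values shown sits. Compound 4 `COc1cc2c(Nc3ccc(C#N)cc3)ncnc2cc1OCCCN1CCC(N(C)C)CC1` carries 4-(dimethylamino)piperidin-1-yl in place of 1,2,3,4-tetrahydroisoquinolin-2-yl on a saturated chain carbon, three bonds along the chain from an oxygen on an aromatic ring. Two measured steps lead to the group now leaving: an at least 12-fold higher number from compound 1 to compound 3 (1.09 log units; beyond the scatter) and an at least 2.1-fold higher number from compound 2 to compound 3 (0.32 log units; beyond the scatter). A third change at this place gave a 5.8-fold higher number from compound 1 to compound 2 (0.77 log units; beyond the scatter). Leaving the group of compound 3 is therefore expected to lower the number by a modest to large amount. The expected step is an at least 6.6-fold lower number from compound 3 to compound 4 (0.82 log units; beyond the scatter). For compound 4 the estimate is 15000 nM, with an expected range of 4000 nM to 60000 nM.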

Compound 4, half-maximal inhibitory concentration: 24300 nM
The estimate for compound 4 lay 1.6-fold (0.21 log units) below the measured number, within the range that was stated.
By their numbers in this assay, from the lowest: compound 1; then compounds 4 and 2 (each within the scatter of the next). At a limit, above all of these: compound 3.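

Replacing 1,2,3,4-tetrahydroisoquinolin-2-yl with 4-(dimethylamino)piperidin-1-yl gave an at least 4.1-fold lower number from compound 3 to compound 4 (0.61 log units; beyond the scatter), a step read from a limit: the limit of > 100000 nM in this assay, at which 1 of the 4 values shown sits.

Dimethylamino in place of ethoxycarbonyl on a saturated ring carbon gave a 1.9-fold lower number from compound 2 to compound 4 (0.29 log units; within the scatter), so the two substituents could not be told apart in this assay. The pyrrolidin-1-yl chain end still gave the lowest number, with a 3.0-fold higher number from compound 1 to compound 4 (0.48 log units; beyond the scatter).

The compounds shown leave open how a carboxylic acid or a primary amine on that ring carbon would read. They also leave open whether a longer chain would keep this order.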